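From compound 3 to compound 4: one ring exchanged

The source may report more compounds than this note shows. Statements on the series, on what has been measured and on what is new or still open speak of the compounds shown alone.

Three compounds have been measured in an ADME assay on a cell-free system (plasma, Rattus norvegicus) for protein binding:

- compound 1 `CNc1nccc(N2CC[C@H](NC(=O)Nc3ccc(CN(C)C)c(C(F)(F)F)c3)C2)n1` gives 91%
- compound 2 `CNc1nccc(N2CC[C@H](NC(=O)Nc3ccc(Cl)c(C(F)(F)F)c3)C2)n1` gives 99.7%
- compound 3 `CNc1nccc(N2CC[C@H](NC(=O)Nc3ccc(CN4CCCC4)c(C(F)(F)F)c3)C2)n1` gives 87.8%

Compound 3 stands with compound 1, with a 1.4-fold higher unbound fraction from compound 1 to compound 3 (0.13 log units; within the scatter). It stands far from compound 2, with a 41-fold higher unbound fraction from compound 2 to compound 3 (1.61 log units; beyond the scatter). The other large step is a 30-fold lower unbound fraction from compound 1 to compound 2 (1.48 log units; beyond the scatter), and both large steps exchange chloro with a group carried on a saturated chain carbon.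

Compound 4 `CCN1CCN(Cc2ccc(NC(=O)N[C@H]3CCN(c4ccnc(NC)n4)C3)cc2C(F)(F)F)CC1` involves no such exchange. The difference is 4-ethylpiperazin-1-yl in place of pyrrolidin-1-yl on a saturated chain carbon bound to an aromatic carbon, so 4-ethylpiperazin-1-yl stands in place of pyrrolidin-1-yl on a saturated chain carbon bound to an aromatic carbon. Among the compounds with values here, the nearest precedent is the change at that same place from compound 1 to compound 3, which gave a 1.4-fold higher unbound fraction from compound 1 to compound 3 (0.13 log units; within the scatter). Within the data shown here, that single step is thin support, and no measured compound carries 4-ethylpiperazin-1-yl. Even so, no step beyond the scatter is expected in this assay, and the direction remains open.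

The expected change is a 1.2-fold lower unbound fraction from compound 3 to compound 4 (0.09 log units; within the scatter). For compound 4 the estimated value is 90%, with an expected range of 82% to 96%.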

Compound 4, plasma protein binding: 84.2%
Estimate against measurement, compound 4: 1.6-fold (0.20 log units) (unbound fraction) below, within the range that was stated.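

In this assay, the place on a saturated chain carbon bound to an aromatic carbon now also holds a six-membered ring with a second nitrogen and an ethyl group, with no step beyond the scatter against either earlier amine (a 1.3-fold higher unbound fraction from compound 3 to compound 4 (0.11 log units; within the scatter); a 1.8-fold higher unbound fraction from compound 1 to compound 4 (0.24 log units; within the scatter)). The groups dimethylamino, pyrrolidin-1-yl and 4-ethylpiperazin-1-yl therefore cannot be told apart in this assay, while the large gap to chloro on the aromatic carbon holds for the new group as well (a 53-fold higher unbound fraction from compound 2 to compound 4 (1.72 log units; beyond the scatter)). Nothing measured here gives a reason for the flat steps among these amines or for the large steps from chloro.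

The compounds shown leave open whether the gap to chloro depends on the amine nitrogen itself, which morpholin-4-yl or a carboxylic acid carried on the same saturated chain carbon would test. They also leave open whether the flat steps would survive a longer chain between the aromatic carbon and the amine, or a piperazin-1-yl ring without the ethyl group.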